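Chloro added to the trifluoromethylphenyl of compound 3

The source may hold more compounds than are shown below. What is called first, only, known or untested is meant among the compounds shown, and "the series" means these compounds.

Within the data shown here, compound 3 `COc1cc(-c2nn(-c3cccc(NC(=O)Nc4cccc(C(F)(F)F)c4)c3)cc2-c2ccncc2)ccc1Cl` gives 1280 nM in a functional assay on 786-0 cells (Homo sapiens) for inhibition, read by sulforhodamine B assay, with a stated time of 48 h (a higher number here means a weaker inhibitor of growth, a lower number a stronger inhibitor of growth), the lowest of the three numbers so far. Compound 2 `COc1cc(-c2nn(-c3cccc(NC(=O)c4cccc(C(F)(F)F)c4)c3)cc2-c2ccncc2)ccc1Cl` gives 2450 nM, and the step of a 1.9-fold lower number from compound 2 to compound 3 (0.28 log units; within the scatter) stays within the scatter, so the two are not ordered. Compound 1 `O=C(Nc1cccc(-n2cc(-c3ccncc3)c(-c3ccc(Cl)c(O)c3)n2)c1)Nc1cccc(C(F)(F)F)c1` gives 4690 nM, and the step of a 3.7-fold lower number from compound 1 to compound 3 (0.56 log units; beyond the scatter) is beyond the scatter. Compound 4 `COc1cc(-c2nn(-c3cccc(NC(=O)Nc4ccc(Cl)c(C(F)(F)F)c4)c3)cc2-c2ccncc2)ccc1Cl` differs from compound 3 by chloro in place of hydrogen on an aromatic carbon. Neither measured step touches the trifluoromethylphenyl ring: one exchanges methyl for hydrogen on an oxygen, the other changes the link at the carbonyl carbon. Among the measured compounds shown here, no measured step therefore bears on this change, and a step within the scatter is expected in this assay, with no direction favoured. For compound 4 the estimate is 1000 nM, range 400 nM to 3000 nM. The expected step is a 1.3-fold lower number from compound 3 to compound 4 (0.11 log units; within the scatter).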

Compound 4, concentration for 50% growth inhibition: 1610 nM
For compound 4 the middle estimate is 1.6-fold (0.21 log units) below the measured one; the measured number falls inside the stated range.
By their numbers in this assay, from the lowest: compounds 3, 4, 2 and 1 (each within the scatter of the next, the first and the last beyond it).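

Chloro in place of hydrogen, ortho to a trifluoromethyl group and para to a large group, gives a 1.3-fold higher number from compound 3 to compound 4 (0.10 log units; within the scatter) in this assay, so this position accepts chloro with no readable shift. With chloro present, (4-chloro-3-(trifluoromethyl)phenyl)amino in place of 3-(trifluoromethyl)phenyl on the carbonyl carbon gives a 1.5-fold lower number from compound 2 to compound 4 (0.18 log units; within the scatter) and likewise separates nothing. No other data bear on this result.

From the compounds shown here alone, whether an amine, a carboxylic acid or a methoxy group at this position would shift the number beyond the scatter stays open. So does the effect of chloro on compound 2 itself.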